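A few compounds are considered here, and "the series" means these few. Any claim that something is new, unique, unknown or untested is made for them only; others in the source may bear on it.

Measured in a functional assay on NRK-49F cells (Rattus norvegicus) for cytotoxicity, read by MTT assay, with a stated time of 24 h; a higher number here means a weaker inhibitor, a lower number a stronger inhibitor:
- Compound 1 `C/C(=N\NC(=O)/C(C#N)=C/c1ccccc1)c1c(O)c2ccc(O)cc2oc1=O`: 55500 nM
- Compound 2 `COc1ccc(/C=C(\C#N)C(=O)N/N=C(\C)c2c(O)c3ccc(O)cc3oc2=O)cc1OC`: 45300 nM
- Compound 3 `COc1cc(/C=C(\C#N)C(=O)N/N=C(\C)c2c(O)c3ccc(O)cc3oc2=O)cc(OC)c1OC`: 55300 nM

Compound 2 stands within the scatter of both compound 1 and compound 3, so these numbers give it no real separation from either. The next compound, compound 4 `C/C(=N\NC(=O)/C(C#N)=C/c1ccc(Br)cc1)c1c(O)c2ccc(O)cc2oc1=O`, has not yet been measured. It differs from compound 2 as follows: 4-bromophenyl in place of 3,4-dimethoxyphenyl on a double-bonded chain carbon bound to a double-bonded chain carbon. Thus 4-bromophenyl replaces 3,4-dimethoxyphenyl on a double-bonded chain carbon bound to a double-bonded chain carbon.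

Within the data shown here, two measured steps bear on this change. Placing 3,4-dimethoxyphenyl instead of phenyl at that same position gave a 1.2-fold lower number from compound 1 to compound 2 (0.09 log units; within the scatter). Adding a methoxy in place of hydrogen on an aromatic carbon gave a 1.2-fold higher number from compound 2 to compound 3 (0.09 log units; within the scatter). Among the measured compounds shown here, neither step exceeded the scatter, although no measured compound carries bromine, so that group remains untested. No change beyond the scatter is therefore expected in this assay. The estimated step is a 1.1-fold higher number from compound 2 to compound 4 (0.03 log units; within the scatter). For compound 4 the expected value is 48000 nM, with an estimated range from 24000 nM to 90000 nM.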

Compound 4, half-maximal inhibitory concentration: 49600 nM
Compound 4: the middle estimate sits 1.0-fold (0.01 log units) below what was measured, and the stated range covers the measured number.
By their numbers in this assay, from the lowest: compounds 2, 4, 3 and 1 (each within the scatter of the next).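

In this assay, the position on a double-bonded chain carbon bound to a double-bonded chain carbon now also accepts a bromine-bearing ring: 4-bromophenyl in place of 3,4-dimethoxyphenyl gives a 1.1-fold higher number from compound 2 to compound 4 (0.04 log units; within the scatter), and bromo in place of hydrogen on an aromatic carbon gives a 1.1-fold lower number from compound 1 to compound 4 (0.05 log units; within the scatter). The entering and leaving groups differ in heavy atoms and in hydrogen-bond acceptors, yet both steps stay within the scatter, so among the four compounds shown neither methoxy nor bromo separates from the unsubstituted phenyl. No evidence is available on why these readings stay so close.

Every compound shown carries a substituted or plain phenyl at this position, so an amine or a carboxylic acid on that ring remains open. Whether any group here can move the number beyond the scatter is also unresolved.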